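Cytotoxicity across the shared core: thiophenyl replaces cyanophenyl

The compounds below may be only part of what the source reports. "The series", "measured", "known", "first", "only" and "open" are said of these compounds alone.

Compound 1 `N#Cc1ccc(-c2cc(Cl)cn3c([N+](=O)[O-])c(CS(=O)(=O)c4ccccc4)nc23)cc1` in an ADME assay on HepG2 cells (Homo sapiens) for cytotoxicity, read by MTT assay, with a stated time of 72 h; a higher number here means that more compound is tolerated, a lower number that less compound is tolerated: compound 1 gives > 3900 nM, a limit of the assay.
Compound 2 `O=[N+]([O-])c1c(CS(=O)(=O)c2ccccc2)nc2c(-c3ccc(O)cc3)cc(Cl)cn12`: compound 2 gives > 12500 nM, again a limit.
Compound 3 `O=[N+]([O-])c1c(CS(=O)(=O)c2ccccc2)nc2c(-c3ccc(CO)cc3)cc(Cl)cn12`: compound 3 gives 13100 nM.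

Compound 1 stands only as a limit in this assay, and one further value of the three is also a limit. The steps a step that the two limits leave unreadable from compound 1 to compound 2 and a step that the limit leaves unreadable from compound 1 to compound 3 cannot be sized because the limit of > 3900 nM in this assay, at which 1 of the 3 values shown sits, hides where compound 1 truly lies. The step that the limit leaves unreadable from compound 2 to compound 3 is likewise unreadable because the limit of > 12500 nM in this assay, at which 1 of the 3 values shown sits, caps compound 2. What the numbers do show is that none of the three compounds is toxic to these cells at the concentrations reached.

Compound 4 `O=[N+]([O-])c1c(CS(=O)(=O)c2ccccc2)nc2c(-c3cccs3)cc(Cl)cn12` differs from compound 1 by thiophen-2-yl in place of 4-cyanophenyl on an aromatic carbon. Among the measured compounds shown here, no measured step concerns this change, so the expectation rests on the whole set sitting at or near the upper end of the assay. Compound 4 is therefore expected to give 10000 nM in this assay, with a range from 3000 nM to 30000 nM. Against compound 1 this expected value means the step that the limit leaves unreadable from compound 1 to compound 4, which is an estimate and not a reading.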

Compound 4, half-maximal cytotoxic concentration: > 3900 nM
Compound 4: a limit, no number (the forecaster's own chance of this, stated with the estimate: 50%); the middle value does not contradict the limit.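

In this assay compound 4 gives > 3900 nM, a limit, so its steps to compound 1, compound 2 and compound 3 cannot be read. The compounds shown leave open where compound 4 truly lies and whether thiophen-2-yl in place of 4-cyanophenyl changes tolerance at all.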